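Furan-2-ylmethyl in Place of a Pyrrolidine Chain

A few compounds are considered here, and "the series" means these few. Any claim that something is new, unique, unknown or untested is made for them only; others in the source may bear on it.

Two compounds from this series have numbers in an assay on isolated protein for inhibition of ubiquitin carboxyl-terminal hydrolase 7 (Homo sapiens), read by TR-FRET, with stated times of 75 min and 1 h; a higher number here means a weaker inhibitor, a lower number a stronger inhibitor. Compound 1 `CC(CC(=O)N1CCC(O)(CN2C=Nc3cc(NCCN(C)C)ccc3C2O)CC1)c1ccccc1` gives 1540 nM in this assay. Compound 2 `O=C(CCc1ccccc1)N1CCC(O)(CN2C=Nc3cc(NCCN4CCCC4)ccc3C2O)CC1` gives 4860 nM in this assay, the higher of the two numbers, and its gap to compound 1 lies beyond the usual scatter of the measurement.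

Compound 3 `O=C(CCc1ccccc1)N1CCC(O)(CN2C=Nc3cc(NCc4ccco4)ccc3C2O)CC1` has not yet been measured. It differs from compound 2 in one place: furan-2-yl in place of (pyrrolidin-1-yl)methyl on a saturated chain carbon bound to a nitrogen on an aromatic ring. Among the measured compounds shown here, no pair differing in a single place has been measured here, so there is no direct precedent for the size of such a step in this assay.

On that basis the author expects the change from compound 2 to compound 3 to leave the number roughly where it is, with a step of a 1.2-fold lower number from compound 2 to compound 3 (0.08 log units; within the scatter) that is expected to stay within or only slightly beyond the scatter, in either direction. For compound 3 the estimate in this assay is 4000 nM, expected to fall between 1200 nM and 14000 nM.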

Compound 3, half-maximal inhibitory concentration: 9800 nM
Compound 3: the middle estimate sits 2.5-fold (0.39 log units) below what was measured, within the range that was stated.
By their numbers in this assay, from the lowest: compound 1; then compounds 2 and 3 (each within the scatter of the next).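

In this assay, among the compounds shown here, compound 2 and compound 3 form the first pair that differ in one place, and they give a direct reading of the group on a saturated chain carbon bound to a nitrogen on an aromatic ring. The step is a 2.0-fold higher number from compound 2 to compound 3 (0.30 log units; within the scatter), so the assay does not separate the two compounds, even though the (pyrrolidin-1-yl)methyl group, a non-aromatic ring holding nitrogen, and the furan-2-yl group, an aromatic ring holding oxygen, differ in ring type and hetero atom. For this one pair, then, the pyrrolidine nitrogen is not needed to keep the number within the scatter, although no measurement is available that explains this result.

Going by these compounds, one pair cannot show whether this place accepts other groups in general, and it remains open whether a primary amine, a carboxylic acid or a longer chain ending in a phenyl ring would bring a step beyond the scatter. On these data alone, it is also open whether the same exchange would give a similar step on the core and acyl chain of compound 1.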